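Ring Size at the Thiocarbonyl Carbon and Growth Inhibition

The source may report more compounds than this note shows. Statements on the series, on what has been measured and on what is new or still open speak of the compounds shown alone.

Compound 1, `Cc1ccnc(/C(N)=N/NC(=S)N2CCOCC2)c1`: 6.86%
Compound 2, `Cc1ccnc(/C(N)=N/NC(=S)N2CCCCC2)c1`: 40.7%

In a functional assay on MCF7 cells (Homo sapiens) for cytotoxicity, read by MTT assay, with a stated time of 72 h, tested at 10 uM (on this read-out higher numbers stand for more inhibition of growth at the one concentration tested and lower numbers for less inhibition of growth), compound 1 gives 6.86% and compound 2 gives 40.7%. Compound 2 stands highest of the two numbers; its nearest neighbour is compound 1, and the step between them is a number 33.8 percentage points higher from compound 1 to compound 2 (beyond the scatter), a large one.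

Compound 3, `Cc1ccnc(/C(N)=N/NC(=S)N2CCCC2)c1`, differs from compound 2 by pyrrolidin-1-yl in place of piperidin-1-yl on a thiocarbonyl carbon. Among the compounds with values here, the only measured step that touches this position is the one from compound 1 to compound 2, in which morpholin-4-yl gave way to piperidin-1-yl, and it was large. Within the data shown here, the change to compound 3 is of a different kind: it keeps a ring of carbon and nitrogen only and exchanges the six-membered ring for a five-membered one, and no measured pair shows which way such a change runs. The expectation therefore leans on compound 2 as the closest analogue, with a modest downward step allowed for the unknown effect of the smaller ring: a number 10.7 percentage points lower from compound 2 to compound 3 (beyond the scatter) is expected. Compound 3 is estimated at 30%, with a range from 8% to 52%.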

Compound 3, percent growth inhibition at one concentration: 63.6%
For compound 3 the middle estimate is 33.6 percentage points below the measured one, outside the stated range (above it).
By their numbers in this assay, from the lowest: compound 1; then compound 2; then compound 3.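

In this assay, replacing piperidin-1-yl with pyrrolidin-1-yl on the thiocarbonyl carbon gives a number 22.9 percentage points higher from compound 2 to compound 3 (beyond the scatter), so this position responds to a change of ring size alone, even with the ring still holding carbon and nitrogen only. Measured against the morpholin-4-yl compound, the same pyrrolidin-1-yl group gives a number 56.7 percentage points higher from compound 1 to compound 3 (beyond the scatter), which makes compound 3 the highest of the three, with its steps to both others beyond the scatter and the full span at this position wider than the earlier step had shown. No supporting data accompany these results to explain why the five-membered ring reads higher than either six-membered ring.

The compounds shown leave open how azetidin-1-yl, azepan-1-yl or an open-chain dimethylamino group on the thiocarbonyl carbon would read, so it cannot be told whether the rise follows ring size or belongs to pyrrolidin-1-yl alone. They also leave open whether the order of these three compounds would hold at other concentrations or in other cell lines, since each number here comes from a single tested concentration in one cell line.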